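This account rests on a few compounds, and the source may have more. Where it says the series, first, only, none or still open, it means among the compounds named here.

Going by the values given here, compound 2, `Cc1cccc(NC(=S)N/N=C/c2ccc(O)cc2)c1`, is one of two compounds measured in an assay for inhibition of ribonucleoside-diphosphate reductase RR1 (Homo sapiens), with a stated time of 30 min (a higher number here means a weaker inhibitor, a lower number a stronger inhibitor), where compound 2 gives 30400 nM. Among the compounds with values here, its only companion is compound 1, `Oc1ccc(/C=N/NC(=S)Nc2cccc(Cl)c2)cc1`, which in this assay gives 29300 nM. The step of a 1.0-fold higher number from compound 1 to compound 2 (0.02 log units; within the scatter) is within the scatter, so the two compounds stand together rather than in any order, and no difference in potency between them can be claimed.

Compound 3, `Oc1ccc(/C=N/NC(=S)Nc2cccc(O)c2)cc1`, is the next compound to be tested. Its change from compound 2 is hydroxy in place of methyl on an aromatic carbon. Within the data shown here, the one measured step that touches the same position, a 1.0-fold higher number from compound 1 to compound 2 (0.02 log units; within the scatter), left the number essentially unchanged, but it exchanged two groups that carry no hydrogen-bond donor or acceptor, whereas the entering hydroxy brings one of each. Among the measured compounds shown here, the data give no measured example of such an exchange, so the direction of any effect is open.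

For the measured compounds named here, on the single step available, compound 3 is expected to give about 30000 nM in this assay, within a range of 12000 nM to 75000 nM, which means an estimated step of a 1.0-fold lower number from compound 2 to compound 3 (0.01 log units; within the scatter), that is none beyond the scatter.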

Compound 3, half-maximal inhibitory concentration: 28600 nM
The estimate for compound 3 lay 1.0-fold (0.02 log units) above the measured number; low and high end bracket the measured number.
By their numbers in this assay, from the lowest: compounds 3, 1 and 2 (each within the scatter of the next).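

Going by these compounds alone, with hydroxy, a group carrying a hydrogen-bond donor and acceptor enters this aromatic carbon for the first time, and in this assay its exchange for methyl gives a 1.1-fold lower number from compound 2 to compound 3 (0.03 log units; within the scatter), while its exchange for chloro gives a 1.0-fold lower number from compound 1 to compound 3 (0.01 log units; within the scatter). Both steps lie within the scatter, so methyl, chloro and hydroxy at this place, meta to a large group, stand together, and the entry of a hydrogen-bond donor and acceptor goes with no readable change in the number across these three compounds. Nothing measured here offers an explanation for this flat result.

Whether the number would stay the same with an amine, a carboxylic acid or a longer chain at this place remains open, since only three small groups are shown there. On these data alone, it is also open whether the same groups would behave alike elsewhere on the ring, or whether a ring with a hydrogen in place of any of them would give a number in the same range.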